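The source may report more compounds than this note shows. Statements on the series, on what has been measured and on what is new or still open speak of the compounds shown alone.

Working notes on the series. Two compounds have numbers in a functional assay on HepG2 cells (Homo sapiens) for cytotoxicity, read by MTT assay (on this read-out higher numbers stand for weaker inhibition and lower numbers for stronger inhibition), so far. Compound 1 `O=c1cc(C2CCCC2)oc2ccc(Cl)cc12` gives 13400 nM in this assay. Compound 2 `CC(C)c1ccc2oc(C3CCCCC3)cc(=O)c2c1` gives 18000 nM in this assay; this is the higher of the two numbers, but the gap to compound 1 lies within the scatter of repeated measurements, so the two compounds cannot be told apart on these data.

Compound 3 `CC(C)c1ccc2oc(C3CCCC3)cc(=O)c2c1` is not yet measured. It differs from compound 2 in one place: cyclopentyl in place of cyclohexyl on an aromatic carbon. Within the data shown here, no pair of measured compounds shows this change on the shared core, so nothing measured tells how large a step to expect. For compound 3 the step from compound 2 is expected to be small, a 1.2-fold lower number from compound 2 to compound 3 (0.08 log units; within the scatter), in no particular direction and not beyond the scatter. The number for compound 3 in this assay is therefore estimated at 15000 nM, with a range from 7000 nM to 35000 nM.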

Compound 3, half-maximal inhibitory concentration: 8600 nM
For compound 3 the middle estimate is 1.7-fold (0.24 log units) above the measured one; the range from low to high includes it.
By their numbers in this assay, from the lowest: compounds 3, 1 and 2 (each within the scatter of the next, the first and the last beyond it).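

In this assay, cyclopentyl in place of cyclohexyl next to the ring oxygen gives a 2.1-fold lower number from compound 2 to compound 3 (0.32 log units; beyond the scatter), the first sign in the series that the group at this position can move the read-out, although the step is only modest and rests on a single pair. With cyclopentyl held fixed, isopropyl in place of chloro gives a 1.6-fold lower number from compound 1 to compound 3 (0.19 log units; within the scatter), so that change leaves the two compounds indistinguishable on these data. Nothing at hand bears on the reason for either step.

On these data alone, whether the ring change gives a similar step with chloro in place of isopropyl on the shared core remains open. Also open, as far as these compounds go, is how a smaller ring such as cyclopropyl, an open chain such as tert-butyl, or a ring carrying an amine such as piperidinyl would read at this position.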